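Methyl on the Phenyl Ring: From Compound 3 to Compound 4

The source may hold more compounds than are shown below. What is called first, only, known or untested is meant among the compounds shown, and "the series" means these compounds.

Three pyrazole diesters have been measured in a functional assay on HeLa cells (Homo sapiens) for cytotoxicity, read by MTT assay, with a stated time of 48 h; a higher number here means a weaker inhibitor, a lower number a stronger inhibitor. Compound 1 `CCOC(=O)c1c(-c2c(Cl)c3cc(C)ccc3oc2=O)nn(-c2ccccc2)c1C(=O)OCC` gives 228000 nM in this assay, and compound 2 `CCOC(=O)c1c(-c2c(Cl)c3cc(C)ccc3oc2=O)nn(-c2cccc(C)c2)c1C(=O)OCC` gives 115000 nM. The two differ only by methyl in place of hydrogen on an aromatic carbon, and that change made a 2.0-fold lower number from compound 1 to compound 2 (0.30 log units; within the scatter). Compound 3 `COC(=O)c1c(-c2cc3ccccc3oc2=O)nn(-c2ccccc2)c1C(=O)OC` carries a different core; how its core differs from that of compound 1 is not broken down here. In this assay compound 3 gives 35000 nM, the lowest of the three numbers, and its steps to compound 2 and to compound 1 are both beyond the scatter.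

Compound 4 `COC(=O)c1c(-c2cc3ccccc3oc2=O)nn(-c2cccc(C)c2)c1C(=O)OC` is not yet measured. It differs from compound 3 by methyl in place of hydrogen on an aromatic carbon, the same change already seen from compound 1 to compound 2. For compound 4 the expected step is a 1.8-fold lower number from compound 3 to compound 4 (0.24 log units; within the scatter), of about the size seen in the earlier pair because a 2.0-fold lower number from compound 1 to compound 2 (0.30 log units; within the scatter) was small and within the scatter. On that basis compound 4 is estimated at 20000 nM in this assay, expected to fall between 8000 nM and 50000 nM.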

Compound 4, half-maximal inhibitory concentration: 45000 nM
Compound 4: the middle estimate sits 2.3-fold (0.35 log units) below what was measured; low and high end bracket the measured number.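

In this assay, the change from phenyl to 3-methylphenyl gave a 1.3-fold higher number from compound 3 to compound 4 (0.11 log units; within the scatter), so on this core, as on the core of compound 1, the methyl produced no step beyond the scatter. Set side by side, the two steps cannot be told apart: the same change on two cores in this assay, a 2.0-fold lower number (0.30 log units; within the scatter) from compound 1 to compound 2 and a 1.3-fold higher number (0.11 log units; within the scatter) from compound 3 to compound 4, 2.5-fold (0.41 log units) apart, within the scatter of two such steps. This shows that the change behaved alike within the scatter on both cores, but it does not show that the methyl has any real effect on either core, and two pairs cannot say whether the same would hold on a third core.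

The compounds shown leave open whether a group other than methyl in the same place, such as a chlorine atom, a methoxy group, an amine or a carboxylic acid, would give a step beyond the scatter. They also leave open how a longer chain on the esters of compound 3 and compound 4 would alter the number.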